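This account rests on a few compounds, and the source may have more. Where it says the series, first, only, none or still open, it means among the compounds named here.

Compound 1 `Cc1ccc(-c2nc3ccc(Cl)cc3c(=O)[nH]2)cc1` is the anchor of this small set. In a functional assay on HeLa cells (Homo sapiens) for antiproliferative activity, read by MTT assay, with a stated time of 48 h (a lower number here means a stronger inhibitor, a higher number a weaker inhibitor), compound 1 gives 10.1 ug/mL. Compound 2 `Cc1ccc(-c2nc(NO)c3cc(Cl)ccc3n2)cc1` gives 12.7 ug/mL in this assay, and compound 3 `Cc1ccc(-c2nc(NC(=O)c3ccccc3)c3cc(Cl)ccc3n2)cc1` gives 16.2 ug/mL, so the three numbers sit close together and none of them separates from another beyond the scatter.

The move to compound 4 `Cc1ccc(-c2nc3ccc(Cl)cc3c(=O)n2N)cc1` is the change (amino in place of hydrogen on an aromatic nitrogen). Going by the values given here, only one measured step touches a change at a nitrogen on the shared core: a 1.3-fold higher number from compound 2 to compound 3 (0.11 log units; within the scatter), a replacement of a group on a nitrogen that left the number where it was. That step concerns a different nitrogen and a different pair of groups, so it bears on the present change only as a sign that this region of the core has so far tolerated substitution without a shift. On that basis no step beyond the scatter is expected in this assay, in either direction.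

Compound 4 is therefore estimated at 10 ug/mL, with a range from 4 ug/mL to 25 ug/mL, which means an expected step of a 1.0-fold lower number from compound 1 to compound 4 (0.00 log units; within the scatter).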

Compound 4, half-maximal inhibitory concentration: 12.1 ug/mL
Compound 4: middle estimate off by 1.2-fold (0.08 log units), on the low side, and the stated range covers the measured number.
By their numbers in this assay, from the lowest: compounds 1, 4, 2 and 3 (each within the scatter of the next).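

In this assay, the reading is a 1.2-fold higher number from compound 1 to compound 4 (0.08 log units; within the scatter), so amino on the aromatic nitrogen of the shared core, where compound 1 carries hydrogen, gives a number within the scatter of compound 1. Going by these compounds alone, this is the first direct reading at this nitrogen, since the earlier step between compound 2 and compound 3 concerned a different nitrogen, and it shows that a group of this size is tolerated here, ortho to a group of 7 heavy atoms. Nothing at hand explains this outcome or ties it to any property of the amino group.

The compounds shown leave open whether a methyl, an acetyl or a longer alkyl chain on this nitrogen would also stay within the scatter. Within the data shown here, with amino as the only group here, they also do not show how large a group this position accepts.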